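The compounds below may be only part of what the source reports. "The series", "measured", "known", "first", "only" and "open" are said of these compounds alone.

Compounds measured so far:

compound 1, `CCOC(=O)C1=C(C)NC(=O)NC1C1CCCC1`, 18%
compound 2, `CC1=C(C(=O)OC(C)C)C(c2ccsc2)N/C(=N/C#N)N1`, 13%
compound 3, `CCOC(=O)C1=C(C)N/C(=N\C#N)NC1c1ccsc1`, 23%

Of the compounds shown here, three have been tested in an assay on HeLa cells for displacement of a labelled ligand from adenosine receptor A3 (Homo sapiens), with a stated time of 180 min, tested at 1 uM; a lower number here means less inhibition, a higher number more inhibition at the concentration tested (going by the name of the read-out). Compound 1 gives 18%, compound 2 gives 13%, and compound 3 gives 23%. All three numbers sit within the scatter of one another, so none of them can be said to give a higher or lower number than the others.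

The compound still to be measured is compound 4, `CC1=C(C(=O)OC(C)C)C(C2CCCC2)NC(=O)N1`. It stands to compound 1 as compound 2 stands to compound 3: the change is methyl in place of hydrogen on a saturated chain carbon bound to an oxygen next to a carbonyl group and a saturated chain carbon, and between compound 3 and compound 2 it reads (methyl in place of hydrogen on a saturated chain carbon bound to an oxygen next to a carbonyl group and a saturated chain carbon). The place of the change is described in the same words in both pairs, so it is the same change made on two different cores. How the core of compound 1 differs from that of compound 3 is not broken down here. Among the compounds shown the change occurs twice, and where it is measured it made a number 10 percentage points lower from compound 3 to compound 2 (within the scatter).

Resting on that one measured step, compound 4 is expected to show a number 8 percentage points lower from compound 1 to compound 4 (within the scatter) in this assay, with nothing beyond the pair of compound 3 and compound 2 to support it. The estimate for compound 4 is 10%, expected to fall between 0% and 25%.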

Compound 4, a percentage reported as inhibition, at one concentration (the size of the read-out at that concentration, not a potency): 7%
Estimate against measurement, compound 4: 3 percentage points above; measured number inside the range.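

In this assay the change from ethoxycarbonyl to isopropoxycarbonyl gave a number 11 percentage points lower from compound 1 to compound 4 (beyond the scatter) and so came out at much the same size on both cores: the same change on two cores in this assay, a number 10 percentage points lower (within the scatter) from compound 3 to compound 2 and a number 11 percentage points lower (beyond the scatter) from compound 1 to compound 4, 1 percentage points apart, within the scatter of two such steps. Going by these compounds alone, this is a single change compared on only two cores in one assay, so it shows that the two steps agree, but it does not establish a rule for the whole series or for any further core. Within the data shown here, the read-out is also taken at one concentration and gives no potency, and only the step on the core of compound 1 lies beyond the scatter, so the other step offers support in size but does not stand clear on its own.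

The compounds shown leave open whether the same direction holds when the ester carries a longer chain such as butyl, or a ring such as cyclopropyl, in place of isopropyl. They also leave open what happens when the ester is replaced altogether by a carboxylic acid or an amide, on either core.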